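Removing the aromatic ring from the amine side group

This account rests on a few compounds, and the source may have more. Where it says the series, first, only, none or still open, it means among the compounds named here.

Measured in a functional assay on HCT-15 cells (Homo sapiens) for inhibition, read by MTT assay, with a stated time of 72 h; a higher number here means a weaker inhibitor, a lower number a stronger inhibitor:
- compound 1 `COc1cc(Oc2cccc(Nc3ccccc3)c2)cc(OC)c1CNCc1ccccc1`: 5020 nM
- compound 2 `COc1cc(Oc2cccc(Nc3ccccc3)c2)cc(OC)c1CNCc1ccc(F)cc1`: 3640 nM
- compound 3 `COc1cc(Oc2cccc(Nc3ccccc3)c2)cc(OC)c1CN[C@H](C)c1ccccc1`: 7550 nM

Compound 3 carries 1-phenylethyl on its amine nitrogen. Two steps fix its standing in this assay: a 2.1-fold higher number from compound 2 to compound 3 (0.32 log units; beyond the scatter), and a 1.5-fold higher number from compound 1 to compound 3 (0.18 log units; within the scatter). Compound 4 `COc1cc(Oc2cccc(Nc3ccccc3)c2)cc(OC)c1CNC(C)C` changes that group: isopropyl in place of 1-phenylethyl on an amine nitrogen. Going by the values given here, with isopropyl in place of 1-phenylethyl, the aromatic ring leaves, and no measured step removes it. The nearest guides are small edits to that side group, namely a 1.4-fold lower number from compound 1 to compound 2 (0.14 log units; within the scatter) and a 1.5-fold higher number from compound 1 to compound 3 (0.18 log units; within the scatter). They offer no reason to expect a clear shift in either direction, though the uncertainty is wide. The expected change is a 1.1-fold higher number from compound 3 to compound 4 (0.03 log units; within the scatter), which would stay within the scatter. For compound 4 the estimated value is 8000 nM, with an expected range from 3500 nM to 20000 nM.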

Compound 4, half-maximal inhibitory concentration: > 20000 nM
Compound 4 was reported as a limit; the forecaster's own chance of this, stated with the estimate: 10%; middle value at least 2.5-fold (0.39 log units) from the limit.
By their numbers in this assay, from the lowest: compounds 2, 1 and 3 (each within the scatter of the next, the first and the last beyond it). At a limit, above all of these: compound 4.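

Compound 4 gives a limit and not a number in this assay: the limit of > 20000 nM in this assay, at which 1 of the 4 values shown sits. Each step to it is therefore a minimum: an at least 2.6-fold higher number from compound 3 to compound 4 (0.42 log units; beyond the scatter), an at least 3.9-fold higher number from compound 1 to compound 4 (0.60 log units; beyond the scatter) and an at least 5.4-fold higher number from compound 2 to compound 4 (0.73 log units; beyond the scatter). Among these compounds, the three with an aromatic ring in the amine side group all give lower numbers than compound 4, whose isopropyl has no ring.

As far as these compounds go, what counts here, the aromatic ring itself or simply the larger side group, stays open. Cyclohexylmethyl, with a saturated ring, or a longer chain such as hexyl on the amine nitrogen could separate the two.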